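This account rests on a few compounds, and the source may have more. Where it says the series, first, only, none or still open, it means among the compounds named here.

Three compounds built on a shared core have been examined in a functional assay on K562 cells (Homo sapiens) for antiproliferative activity, read by MTT assay, with a stated time of 48 h; on this read-out lower numbers stand for stronger inhibition and higher numbers for weaker inhibition. Compound 1 `CN1C(=O)C2(C(C#N)=C(N)Oc3cc4oc(-c5ccccc5)cc(=O)c4c(O)c32)c2ccccc21` gives > 50000 nM in this assay, and that value is a limit of the assay rather than a number. Compound 2 `N#CC1=C(N)Oc2cc3oc(-c4ccccc4)cc(=O)c3c(O)c2C12C(=O)N(c1ccccc1)c1ccccc12` gives > 50000 nM in this assay, again a limit. Compound 3 `CCN1C(=O)C2(C(C#N)=C(N)Oc3cc4oc(-c5ccccc5)cc(=O)c4c(O)c32)c2cc(C)ccc21` gives > 50000 nM in this assay, also a limit. Compound 2 thus stands at the limit alongside both other measured compounds, and the step that the two limits leave unreadable from compound 1 to compound 2 cannot be read because both of its ends are limits; the limit of > 50000 nM in this assay, at which 3 of the 3 values shown sit, describes where all three values sit. Compound 4 `CC(C)(C)OC(=O)CN1C(=O)C2(C(C#N)=C(N)Oc3cc4oc(-c5ccccc5)cc(=O)c4c(O)c32)c2ccccc21` differs from compound 2 in one place: (tert-butoxycarbonyl)methyl in place of phenyl on an amide-type nitrogen in a ring. Within the data shown here, no measured step bears directly on this change, and the only step made at the same amide-type nitrogen in a ring, methyl to phenyl, was itself unreadable. The measured compounds therefore give no ground to expect a step beyond the scatter in either direction, and the likeliest outcome is that compound 4 also sits at the limit. Compound 4 is accordingly estimated to give about 60000 nM in this assay, with an expected range from 20000 nM to 200000 nM. The step that the limit leaves unreadable from compound 2 to compound 4 that this estimate implies is expected to be none beyond the scatter.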

Compound 4, half-maximal inhibitory concentration: > 50000 nM
Compound 4: no number, only a limit (the forecaster's own chance of this, stated with the estimate: 80%); the middle value is on the limit's open side.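

In this assay compound 4 gives > 50000 nM, which is a limit of the assay and not a number, so the steps from compound 1 and from compound 2 to it cannot be read. The compounds shown leave open whether any group on the amide-type nitrogen in a ring changes activity on these cells: the limit of > 50000 nM in this assay, at which 4 of the 4 values shown sit.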